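Swapping a Dimethylamino Amide for a Tert-butyl Ester

The compounds below may be only part of what the source reports. "The series", "measured", "known", "first", "only" and "open" are said of these compounds alone.

Compound 1 `COC(=O)c1ccc(Oc2ccc3c(c2)B(O)OC3)cn1` in an ADME assay on Jurkat cells (Homo sapiens) for cytotoxicity, read by MTT assay, with a stated time of 72 h (a lower number here means a stronger inhibitor, a higher number a weaker inhibitor), gives > 100000 nM, which is a limit of the assay rather than a number.
Compound 2 `CN(C)C(=O)c1cnc(Oc2ccc3c(c2)B(O)OC3)cn1` in this assay gives > 100000 nM, again a limit.
Compound 3 `CCCCOC(=O)c1cnc(Oc2ccc3c(c2)B(O)OC3)cn1` in this assay gives > 100000 nM, also a limit.

Compound 2 therefore stands only at a limit. The two other values shown are limits as well, so none of the three compounds can be placed relative to another; the limit of > 100000 nM in this assay, at which 3 of the 3 values shown sit, sums up the whole picture. Compound 4 `CC(C)(C)OC(=O)c1cnc(Oc2ccc3c(c2)B(O)OC3)cn1` has not yet been measured. It differs from compound 2 by tert-butoxy in place of dimethylamino on a carbonyl carbon. Among the measured compounds shown here, the one measured step that bears on this is a step that the two limits leave unreadable from compound 2 to compound 3, in which both ends sit at a limit, so its size cannot be read. That step is nonetheless the closest guide, since it also replaces dimethylamino with an alkoxy group, butoxy, on the same carbonyl carbon. With every value at the limit, no step beyond the scatter is expected in this assay in either direction, and compound 4 is expected to sit at the limit too. Compound 4 is accordingly estimated at 150000 nM, with a range from 100000 nM to 300000 nM. This amounts to an expected step that the limit leaves unreadable from compound 2 to compound 4.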

Compound 4, half-maximal inhibitory concentration: > 100000 nM
Compound 4 ended at the assay's limit; the forecaster's own chance of this, stated with the estimate: 90%; the middle value does not contradict the limit.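

Compound 4 also stands at a limit in this assay, so neither its step from compound 2 nor its step from compound 3 can be read. The compounds shown leave open whether changing the group on the carbonyl carbon alters the result at all, since all four share one ceiling: the limit of > 100000 nM in this assay, at which 4 of the 4 values shown sit.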